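From 2-methoxyphenyl to 4-bromophenyl on a shared core

The source may report more compounds than this note shows. Statements on the series, on what has been measured and on what is new or still open speak of the compounds shown alone.

Three compounds share one core and differ only in the group on an amine nitrogen: compound 1 `CCc1ccc(NC2=CC(=O)c3nc4n(c3C2=O)[C@H]2OC[C@@H](O)[C@H]2OC4)cc1`, compound 2 `COc1ccccc1NC1=CC(=O)c2nc3n(c2C1=O)[C@H]1OC[C@@H](O)[C@H]1OC3` and compound 3 `O=C1C=C(Nc2ccc(Br)cc2)C(=O)c2c1nc1n2[C@H]2OC[C@@H](O)[C@H]2OC1`. In a functional assay on ECa-109 cells for inhibition, with ECa-109 cell line (Homo sapiens) as the target, read by sulforhodamine B assay (on this read-out lower numbers stand for stronger inhibition and higher numbers for weaker inhibition), compound 1 gives 3080 nM. Compound 2 gives > 4000 nM, which is a limit of the assay and not a number. On these data alone, this places compound 2 at the limit of > 4000 nM in this assay, at which 1 of the 2 values shown sits, so its exact standing is unknown.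

The next change is 4-bromophenyl in place of 2-methoxyphenyl on an amine nitrogen. Among the measured compounds shown here, only one measured step bears on it: an at least 1.2-fold higher number from compound 1 to compound 2 (0.11 log units; that floor lies within the scatter). That step is small and open-ended, so it offers only weak guidance. Compound 3 carries a 4-substituted phenyl, and the nearest comparison is the 4-ethylphenyl of compound 1 at 3080 nM. In this assay, a slightly lower number is therefore expected, but probably no change beyond the scatter. The expected step is an at least 1.3-fold lower number from compound 2 to compound 3 (0.12 log units; that floor lies within the scatter). Compound 3 is estimated at 3000 nM, with an expected range from 1200 nM to 7000 nM.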

Compound 3, half-maximal inhibitory concentration: 2850 nM
The estimate for compound 3 lay 1.1-fold (0.02 log units) above the measured number; the measured number falls inside the stated range.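

Exchanging ethyl for bromo on the aromatic carbon gives a 1.1-fold lower number from compound 1 to compound 3 (0.03 log units; within the scatter), so in this assay the 4-ethylphenyl and 4-bromophenyl groups on this amine nitrogen cannot be told apart, and two quite different groups are tolerated equally here. The step that replaces 2-methoxyphenyl with 4-bromophenyl is an at least 1.4-fold lower number from compound 2 to compound 3 (0.14 log units; that floor lies within the scatter), and because it is only a floor, the real difference could be small or could be larger. The value of compound 2 is a limit of the assay and not a number: the limit of > 4000 nM in this assay, at which 1 of the 3 values shown sits.

The 2-methoxyphenyl and 4-bromophenyl groups differ both in the substituent and in where it sits on the ring, so a 4-methoxyphenyl group on the same nitrogen is what could separate those two changes. On these data alone, it also remains open whether a 4-aminophenyl group, a 4-carboxyphenyl group or a longer chain in place of ethyl would move the number beyond the scatter, or whether this position stays just as flat for them.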